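Replacing the vinyl on the amide of compound 3

A few compounds are considered here, and "the series" means these few. Any claim that something is new, unique, unknown or untested is made for them only; others in the source may bear on it.

Compounds measured so far in a functional assay on A549 cells (Homo sapiens) for inhibition, read by MTT assay, with a stated time of 72 h; a lower number here means a stronger inhibitor, a higher number a weaker inhibitor:
- compound 1, `COc1ccc(Nc2nc(Oc3cccc(NC(=O)C=C(C)C)c3)c3sccc3n2)cc1`: 18100 nM
- compound 2, `COc1ccc(Nc2nc(Oc3cccc(NC(=O)/C=C/C(C)C)c3)c3sccc3n2)cc1`: 37900 nM
- compound 3, `C=CC(=O)Nc1cccc(Oc2nc(Nc3cccc(OC)c3)nc3ccsc23)c1`: 4340 nM

Compound 3 gives the lowest number of the three, so it is the strongest inhibitor in this set; compound 1 and compound 2 both give clearly higher numbers. Compound 4, `COc1cccc(Nc2nc(Oc3cccc(NC(=O)C=C(C)C)c3)c3sccc3n2)c1`, has not yet been measured. It differs from compound 3 in one place: 2-methylprop-1-en-1-yl in place of vinyl on a carbonyl carbon. Compound 4 and compound 1 therefore carry the same (2-methylprop-1-en-1-yl)carbonyl group on the amide nitrogen and differ elsewhere.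

Going by the values given here, no measured pair shows exactly this change. Among the compounds with values here, the only single-place step in the set, a 2.1-fold higher number from compound 1 to compound 2 (0.32 log units; beyond the scatter), concerns a lengthening of the same alkenyl group on the carbonyl carbon and gave a modest rise. Beyond that, compound 1 gives a higher number than compound 3, though the two differ in more than one place.

On this basis compound 4 is expected to give a higher number than compound 3, by a step of about a 3.2-fold higher number from compound 3 to compound 4 (0.51 log units; beyond the scatter). The estimate for compound 4 in this assay is 14000 nM, with a range from 5000 nM to 40000 nM.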

Compound 4, half-maximal inhibitory concentration: 27700 nM
Beside the measured number, compound 4's estimate is 2.0-fold (0.30 log units) below it; measured number inside the range.
By their numbers in this assay, from the lowest: compound 3; then compounds 1, 4 and 2 (each within the scatter of the next, the first and the last beyond it).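

In this assay, the vinyl on the carbonyl carbon can now be read directly against 2-methylprop-1-en-1-yl with nothing else changed: the swap gives a 6.4-fold higher number from compound 3 to compound 4 (0.80 log units; beyond the scatter), so in this pair the vinyl goes with the stronger inhibitor. The other new pair changes a different place, 3-methoxyphenyl in place of 4-methoxyphenyl on a nitrogen on an aromatic ring, and gives a 1.5-fold higher number from compound 1 to compound 4 (0.18 log units; within the scatter), so these two placements of the methoxy group cannot be told apart here, while the change on the carbonyl carbon can be read. No evidence at hand explains why the vinyl pair behaves this way.

The compounds shown leave open whether a saturated ethyl on the carbonyl carbon would keep the lower number of the vinyl, and how an amine such as a dimethylamino group at the end of the alkenyl chain would read. Going by these compounds alone, also open is whether the two methoxy placements would still match with vinyl on the carbonyl carbon, as the only pair that compares them carries 2-methylprop-1-en-1-yl.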